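The compounds below may be only part of what the source reports. "The series", "measured", "known", "first", "only" and "open" are said of these compounds alone.

Measured so far:
Compound 1, `C[C@@H](CO)NC(=O)c1cnc2ccccc2c1Cl`: in an ADME assay on CCRF-CEM cells (Homo sapiens) for cytotoxicity (on this read-out lower numbers stand for higher toxicity in this test and higher numbers for lower toxicity in this test), compound 1 gives > 100 uM, which is a limit of the test rather than a number.
Compound 2, `O=C(NCCO)c1cnc2ccccc2c1Cl`: in this assay compound 2 gives > 100 uM, again a limit.
Compound 3, `COC(=O)[C@@H](NC(=O)c1cnc2ccccc2c1Cl)[C@@H](C)O`: in this assay compound 3 gives > 100 uM, also a limit.

The change from compound 1 to compound 2 is hydrogen in place of methyl on a saturated chain carbon bound to an amide-type nitrogen and a saturated chain carbon. The step that the two limits leave unreadable from compound 1 to compound 2 has no readable size: two limits frame it. Compound 4, `COC(=O)[C@H](CO)NC(=O)c1cnc2ccccc2c1Cl`, is not yet measured and differs from compound 3 by hydrogen in place of methyl on a saturated chain carbon bound to an oxygen on a saturated carbon and a saturated chain carbon. This is the same kind of change, though the place differs: in compound 1 the carbon is bound to an amide-type nitrogen and a saturated chain carbon, in compound 3 to an oxygen on a saturated carbon and a saturated chain carbon. The difference between the cores of compound 1 and compound 3 is not broken down here. Since the limit of > 100 uM in this assay, at which 3 of the 3 values shown sit, holds for every measured compound, compound 4 is expected to sit at that limit as well, an expected step that the limit leaves unreadable from compound 3 to compound 4. Compound 4 is thus estimated at 150 uM.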

Compound 4, half-maximal toxic concentration: > 100 uM
Compound 4: a limit, no number (the forecaster's own chance of this, stated with the estimate: 85%); the middle value lies beyond the limit too.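

Within the data shown here, compound 4 also gives only a limit of the test, so no step to it from compound 1, compound 2 or compound 3 can be read: the limit of > 100 uM in this assay, at which 4 of the 4 values shown sit. The compounds shown leave open how any of these changes shifts the toxic concentration in this assay, as none of them gives a number.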